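Anilino substituent series: methoxy to acetamido step

A few compounds are considered here, and "the series" means these few. Any claim that something is new, unique, unknown or untested is made for them only; others in the source may bear on it.

Measured so far in a functional assay for inhibition, with Homo sapiens as the target; a lower number here means a stronger inhibitor, a higher number a weaker inhibitor:
compound 1 `CN(C)c1cccc(Nc2nccc(-c3ccccn3)n2)c1` gives 400 nM
compound 2 `CCc1cccc(Nc2nccc(-c3ccccn3)n2)c1` gives 1400 nM
compound 3 `COc1cccc(Nc2nccc(-c3ccccn3)n2)c1` gives 200 nM

Compound 3 holds the lowest number of the three: a 7.0-fold lower number from compound 2 to compound 3 (0.85 log units; beyond the scatter), while a 2.0-fold lower number from compound 1 to compound 3 (0.30 log units; within the scatter), so it is set apart only from compound 2. Compound 4 `CC(=O)Nc1cccc(Nc2nccc(-c3ccccn3)n2)c1` carries acetamido in place of methoxy on an aromatic carbon. Within the data shown here, no measured step exchanges methoxy for acetamido; what bears on it is that each exchange at this aromatic carbon has moved the number by modest amounts at most, a 3.5-fold higher number from compound 1 to compound 2 (0.54 log units; beyond the scatter) being the largest. On this footing only a small shift in this assay is expected for compound 4, toward a higher number if at all. Compound 4 is estimated at 400 nM, with a range of 100 nM to 1600 nM, which means a 2.0-fold higher number from compound 3 to compound 4 (0.30 log units; within the scatter) is expected.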

Compound 4, half-maximal inhibitory concentration: 300 nM
The estimate for compound 4 lay 1.3-fold (0.12 log units) above the measured number; measured number inside the range.
By their numbers in this assay, from the lowest: compounds 3, 4 and 1 (each within the scatter of the next); then compound 2.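

In this assay acetamido, with 4 heavy atoms against 2 for methoxy and an added hydrogen-bond donor, is accommodated on this aromatic carbon, with a 1.5-fold higher number from compound 3 to compound 4 (0.18 log units; within the scatter) and a 1.3-fold lower number from compound 1 to compound 4 (0.12 log units; within the scatter) both staying inside the scatter. Only ethyl stays apart, as a 4.7-fold lower number from compound 2 to compound 4 (0.67 log units; beyond the scatter) gives a further step from compound 2 that lies beyond the scatter. No measurement available here accounts for this separation.

As far as these compounds go, whether a carboxylic acid or a primary amine on this carbon would stay level with compound 4 remains open. So does the outcome for a longer amide chain.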